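The source may report more compounds than this note shows. Statements on the series, on what has been measured and on what is new or still open speak of the compounds shown alone.

In a functional assay on HCT-116 cells (Homo sapiens) for antiproliferative activity, with a stated time of 72 h (a lower number here means a stronger inhibitor, a higher number a weaker inhibitor), compound 1 `CC(=O)Oc1ccccc1/C=C/c1nc2ccccc2c(=O)[nH]1` gives > 25000 nM, which is a limit and not a number. Compound 2 `CC(=O)Oc1ccc(/C=C/c2nc3ccccc3c(=O)[nH]2)c(OC(C)=O)c1`, which carries a further acetoxy in place of hydrogen on an aromatic carbon, gives > 25000 nM, which is also a limit. Compound 3 `COc1ccccc1/C=C/c1nc(Nc2cccc(O)c2)c2ccccc2n1` is the only one of these compounds with an actual number, and it gives 21700 nM in the same test. The picture so far is the limit of > 25000 nM in this assay, at which 2 of the 3 values shown sit, and compound 1 therefore has no number of its own to start from.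

Compound 4 `CCOc1ccccc1/C=C/c1nc2ccccc2c(=O)[nH]1` departs from compound 1 in one place: ethyl in place of acetyl on an oxygen on an aromatic ring. Put differently, acetoxy gives way to ethoxy. For the measured compounds named here, only one measured step bears on this series, a step that the two limits leave unreadable from compound 1 to compound 2, and it offers no size to carry over, and it concerns a different change. No step beyond the scatter is therefore expected in this assay, and no direction can be assigned to one. Compound 4 is expected to stay close to the limit held by compound 1 and compound 2. The step this estimate implies is expected to be a step that the limit leaves unreadable from compound 1 to compound 4 as a rough figure only. For compound 4 the estimated value is 28000 nM, with an expected range from 9000 nM to 60000 nM as its bounds.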

Compound 4, half-maximal inhibitory concentration: 23300 nM
Beside the measured number, compound 4's estimate is 1.2-fold (0.08 log units) above it; the range from low to high includes it.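

Acetoxy giving way to ethoxy, on an oxygen on an aromatic ring whose other neighbours are aromatic carbon, yields an actual number on the core of compound 1: in this assay compound 4 gives 23300 nM. The change reads as an at least 1.0-fold lower number from compound 1 to compound 4 (0.03 log units; that floor lies within the scatter), which is a floor and not a size, so this result shows neither a real gain nor the absence of one. On these data alone, the true size of this step stays unknown, and the step between the other two limit-bound compounds cannot be read at all, because compound 1 and compound 2 have only a limit and no number of their own: the limit of > 25000 nM in this assay, at which 2 of the 4 values shown sit.

The compounds shown leave open whether any other group on this oxygen, such as a longer chain like propyl or butyl, or a chain ending in an amine or a carboxylic acid, would move the number beyond the scatter. They also leave open whether the same swap from acetyl to ethyl would read the same way on the second acetoxy of compound 2.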